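The compounds below may be only part of what the source reports. "The series", "measured", "known", "first", "only" and "open" are said of these compounds alone.

The measured set is small. Compound 1 `O=C(/C=C/c1ccccc1)NCc1ccc(Cl)cc1Cl` is the only amide among the three; in a functional assay on the whole organism for inhibition, with Brassica rapa subsp. chinensis as the target, with a stated time of 3 days, tested at 100 ppm (on this read-out lower numbers stand for less inhibition of growth and higher numbers for more inhibition of growth at the one concentration tested), compound 1 gives 43%. Compound 2 `CCC(C)OC(=O)/C=C/c1ccccc1`, an ester, gives 20% in this assay, and compound 3 `O=C(/C=C/c1ccc(Cl)cc1)OCCOc1ccccc1`, also an ester, gives 0%. On these numbers compound 2 stands second of three: it lies beyond the scatter above compound 3 and beyond the scatter below compound 1, though neither pair differs in only one place, so no single step can be read from them.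

Compound 4 `CCC(C)NC(=O)/C=C/c1ccccc1` has not yet been measured. It differs from compound 2 in one place: (sec-butyl)amino in place of sec-butoxy on a carbonyl carbon. For the measured compounds named here, no measured pair shows this change alone; the nearest hint is compound 1, whose 43% is the highest number seen and which is also an amide, but it carries a different group on the nitrogen. On that thin basis the step from compound 2 to compound 4 is expected to be a modest rise, a number 12 percentage points higher from compound 2 to compound 4 (beyond the scatter), somewhat beyond the scatter. Compound 4 is therefore estimated at 32%, with a range from 10% to 55%.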

Compound 4, percent growth inhibition at one concentration: 77%
The estimate for compound 4 lay 45 percentage points below the measured number; the whole stated range lies below it.
By their numbers in this assay, from the lowest: compound 3; then compound 2; then compound 1; then compound 4.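

In this assay, for the compounds shown here, putting (sec-butyl)amino in place of sec-butoxy on a carbonyl carbon gives a number 57 percentage points higher from compound 2 to compound 4 (beyond the scatter), the first change in the set that can be read on its own. Both groups have the same count of heavy atoms and the same four-carbon chain, so this large step goes with the exchange of oxygen for nitrogen, which also brings in a hydrogen-bond donor and removes a hydrogen-bond acceptor. Nothing measured here explains the size of the step or shows which of these differences matters.

Going by these compounds, whether a (sec-butyl)methylamino group, which lacks the amide hydrogen, would keep this level of growth inhibition remains open. The compounds shown also leave open how a carboxylic acid or a longer chain on the nitrogen would behave on the same carbonyl carbon.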